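This account rests on a few compounds, and the source may have more. Where it says the series, first, only, none or still open, it means among the compounds named here.

Compounds measured in a functional assay on CHO cells for agonist activity at Free fatty acid receptor 1 (Homo sapiens); a lower number here means that less compound is needed, a higher number that more compound is needed for the effect:
compound 1 `Cc1nc(-c2ccc(C(F)(F)F)cc2)sc1CNc1ccc(CC(=O)O)cc1` gives < 10000 nM, a limit of this assay and not a number.
compound 2 `Cc1nc(-c2ccc(C(F)(F)F)cc2)sc1CNc1ccc(OCC(=O)O)cc1` gives 288 nM.

Compound 2 carries the only number shown; the remaining value is a limit. The step that the limit leaves unreadable from compound 1 to compound 2 cannot be sized, as the limit of < 10000 nM in this assay, at which 1 of the 2 values shown sits, shows. Compound 3 `Cc1nc(-c2ccc(C(F)(F)F)cc2)sc1CNc1ccc(C(C)CC(=O)O)cc1` differs from compound 2 by 1-(carboxymethyl)ethyl in place of carboxymethoxy on an aromatic carbon. No readable measured step bears on this change, so no direction can be drawn from the data; a shift of modest size in either way is expected, not clearly beyond the scatter. The step of a 1.6-fold higher number from compound 2 to compound 3 (0.19 log units; within the scatter) is the expected one. Compound 3 is estimated at 450 nM, between 90 nM and 2500 nM.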

Compound 3, half-maximal effective concentration: 58.9 nM
Estimate against measurement, compound 3: 7.6-fold (0.88 log units) above, and the stated range ends above it.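

Replacing carboxymethoxy with 1-(carboxymethyl)ethyl on this aromatic carbon, para to a large group, gives a 4.9-fold lower number from compound 2 to compound 3 (0.69 log units; beyond the scatter). The oxygen attached to the ring in carboxymethoxy is therefore not required for a measurable value at this position, and the chain without it carries the lower number. The steps from compound 1 cannot be read, its value being a limit and not a number: the limit of < 10000 nM in this assay, at which 1 of the 3 values shown sits.

Which part of 1-(carboxymethyl)ethyl carries the step stays open. So does the outcome with a longer chain, or with a tetrazole in place of the carboxylic acid.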